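The compounds below may be only part of what the source reports. "The series", "measured", "known", "first", "only" and "open" are said of these compounds alone.

Of the compounds shown here, three built on one shared core have been tested in a functional assay on DLD-1 cells (Homo sapiens) for antiproliferative activity, read by CellTiter-Glo, with a stated time of 72 h; on this read-out lower numbers stand for stronger inhibition and higher numbers for weaker inhibition. Compound 1 `CC1CCN(C2CCN(S(=O)(=O)c3cccc(C(F)(F)F)c3)CC2)CC1` gives > 5000 nM in this assay, which is a limit of the assay rather than a number, as the limit of > 5000 nM in this assay, at which 1 of the 3 values shown sits, records. Compound 2 `CC1CCN(C2CCN(S(=O)(=O)c3ccc(-c4ccccc4)cc3)CC2)CC1` gives 258 nM in this assay, and compound 3 `CC1CCN(C2CCN(S(=O)(=O)c3ccc(-c4ccc(Cl)cc4)cc3)CC2)CC1` gives 105 nM. The difference between the cores of compound 1 and compound 2 is not broken down here. Compound 3 differs from compound 2 by chloro in place of hydrogen on an aromatic carbon, and this change produced a 2.5-fold lower number from compound 2 to compound 3 (0.39 log units; beyond the scatter). Compound 4 `CC1CCN(C2CCN(S(=O)(=O)c3ccc(Cl)c(C(F)(F)F)c3)CC2)CC1`, not yet measured, differs from compound 1 by chloro in place of hydrogen on an aromatic carbon. This is the same kind of change, though here the place is ortho to a trifluoromethyl group, which is not so in compound 3. Because compound 1 shows only the limit > 5000 nM in this assay, no measured starting number exists from which a step can be sized. A step of the size of a 2.5-fold lower number from compound 2 to compound 3 (0.39 log units; beyond the scatter) is expected to leave compound 4 weak in this assay. Compound 4 is estimated at 4000 nM in this assay, within 1500 nM to 12000 nM. This amounts to an expected at least 1.2-fold lower number from compound 1 to compound 4 (0.09 log units; that floor lies within the scatter).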

Compound 4, half-maximal inhibitory concentration: 17 nM
Estimate against measurement, compound 4: 240-fold (2.37 log units) above; measured number below the stated range.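

In this assay, chloro in place of hydrogen on an aromatic carbon gives an at least 290-fold lower number from compound 1 to compound 4 (2.46 log units; beyond the scatter), which is a large step. Set beside the earlier result, this shows that the change did not keep its size from one core to the other: the same change on two cores in this assay, a 2.5-fold lower number (0.39 log units; beyond the scatter) from compound 2 to compound 3 and an at least 290-fold lower number (2.46 log units; beyond the scatter) from compound 1 to compound 4, at least 110-fold (2.07 log units) apart, beyond the scatter of two such steps. As far as these compounds go, compound 1 sits at a limit and not at a number, so the larger step has only a floor and its true size stays unknown, and the comparison does not show whether the gap comes from the chloro being ortho to a trifluoromethyl group or from some other difference between the cores: the limit of > 5000 nM in this assay, at which 1 of the 4 values shown sits.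

The compounds shown leave open whether another small group in the same place, such as fluoro, methyl or a nitrile, would give a similar step on the core of compound 1. They also leave open whether chloro would still give a step of this kind with a methoxy group in place of the trifluoromethyl group.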